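One aromatic group swapped on a carbonyl carbon

The source may report more compounds than this note shows. Statements on the series, on what has been measured and on what is new or still open speak of the compounds shown alone.

- compound 1 `Cn1cnc(S(=O)(=O)N2C[C@@H]3[C@H](C2)[C@@]3(CNC(=O)c2ccccc2Cl)CC2CC2)c1`: 0.03
- compound 2 `Cn1cnc(S(=O)(=O)N2C[C@@H]3[C@H](C2)[C@@]3(CNC(=O)c2cccc(C(F)(F)F)c2)CC2CC2)c1`: 0.04

Both values come from an ADME assay on a cell-free system (plasma, Homo sapiens) for protein binding; on this read-out lower numbers stand for a smaller free fraction and higher numbers for a larger free fraction. For the measured compounds named here, the only measured step is a 1.3-fold higher number from compound 1 to compound 2 (0.12 log units; within the scatter), so compound 2 cannot be told apart from compound 1. Compound 3 `Cn1cnc(S(=O)(=O)N2C[C@@H]3[C@H](C2)[C@@]3(CNC(=O)c2ccc(Cl)cc2)CC2CC2)c1` has 4-chlorophenyl in place of 3-(trifluoromethyl)phenyl on a carbonyl carbon. The measured step also swapped the group at this place and stayed within the scatter, so it gives no direction for this assay. The expected change is no change at the digits printed from compound 2 to compound 3 (within the scatter), with no step beyond the scatter. For compound 3 the estimated value is 0.04, with an expected range of 0.02 to 0.07.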

Compound 3, unbound fraction: 0.03
For compound 3 the middle estimate is 1.3-fold (0.12 log units) above the measured one, and the stated range covers the measured number.
By their numbers in this assay, from the lowest: compounds 1, 3 and 2 (each within the scatter of the next).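

Putting 4-chlorophenyl in place of 3-(trifluoromethyl)phenyl on this carbonyl carbon gives a 1.3-fold lower number from compound 2 to compound 3 (0.12 log units; within the scatter) in this assay. Putting 4-chlorophenyl in place of 2-chlorophenyl gives no change at the digits printed from compound 1 to compound 3 (within the scatter), so this assay does not separate these three aromatic groups, including the two chlorophenyl groups. Nothing else at hand bears on this result. All three groups are carbon-only aromatic rings carrying halogen atoms. From the compounds shown here alone, whether an amine, a carboxylic acid or a pyridine ring at this place would move the unbound fraction beyond the scatter remains open.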